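The compounds below may be only part of what the source reports. "The series", "measured", "known", "first", "only" and "open" are said of these compounds alone.

Compound 1 `O=C1C=C(NCc2ccccc2)C(=O)c2c1nc1n2[C@H]2OC[C@@H](O)[C@H]2OC1`: > 8000 nM
Compound 2 `O=C1C(Nc2ccccc2F)=CC(=O)c2c1nc1n2[C@H]2OC[C@@H](O)[C@H]2OC1`: > 4000 nM

In a functional assay on MCF7 cells (Homo sapiens) for inhibition, read by sulforhodamine B assay (on this read-out higher numbers stand for weaker inhibition and lower numbers for stronger inhibition), compound 1 gives > 8000 nM, which is a limit of the assay and not a number. Compound 2 gives > 4000 nM, again only a limit. Among the compounds with values here, no measured step therefore guides what comes next.

Compound 3 `O=C1C=C(Nc2ccccc2F)C(=O)c2c1nc1n2[C@H]2OC[C@@H](O)[C@H]2OC1` has not yet been measured. Compared with compound 1, it has 2-fluorophenyl in place of benzyl on an amine nitrogen.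

With compound 1 known only as > 8000 nM, a small expected shift toward stronger inhibition in this assay is the cautious call. The expected change is an at least 1.6-fold lower number from compound 1 to compound 3 (0.20 log units; that floor lies within the scatter). Compound 3 is estimated at 5000 nM, with an expected range of 1200 nM to 20000 nM.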

Compound 3, half-maximal inhibitory concentration: 3640 nM
For compound 3 the middle estimate is 1.4-fold (0.14 log units) above the measured one; the measured number falls inside the stated range.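

In this assay, within the data shown here, putting 2-fluorophenyl in place of benzyl on this amine nitrogen gives an at least 2.1-fold lower number from compound 1 to compound 3 (0.34 log units; beyond the scatter), the first change in this set that can be read as a real shift. Compound 1 gives > 8000 nM, which is a limit, so that step is a floor and the true gap may be wider.

From the compounds shown here alone, whether the gain comes from the fluorine or from losing the carbon that links the ring to the nitrogen stays open, and plain phenyl would separate the two. How a longer chain such as 2-phenylethyl would behave on this nitrogen is also unknown.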